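The compounds below may be only part of what the source reports. "The series", "measured", "known", "first", "only" and "open" are said of these compounds alone.

Measured in a functional assay on HepG2 cells (Homo sapiens) for antiproliferative activity, read by MTT assay, with a stated time of 48 h; a higher number here means a weaker inhibitor, a lower number a stronger inhibitor:
Compound 1 `C=CCN(C)C(=O)c1ccc(C(CC)(CC)c2ccc(OCCC(O)(CC)CC)c(C)c2)n1CC`: > 50000 nM (a limit of the assay, not a number)
Compound 2 `CCn1c(C(=O)N(C)CC(=O)O)ccc1C(CC)(CC)c1ccc(OCCC(O)(CC)CC)c(C)c1`: 5710 nM

Among the measured compounds shown here, compound 2 holds the only true number so far, since the other result is just a limit. Compound 3 `CCn1c(C(=O)NC(CO)CCO)ccc1C(CC)(CC)c1ccc(OCCC(O)(CC)CC)c(C)c1` keeps the shared core and differs at one place: a group of 7 heavy atoms (4 carbon, 1 nitrogen, 2 oxygen; no ring) in place of a group of 6 heavy atoms (3 carbon, 1 nitrogen, 2 oxygen; no ring), on a carbonyl carbon. For the measured compounds named here, only one measured step bears on this change. That step, an at least 8.7-fold lower number from compound 1 to compound 2 (0.94 log units; beyond the scatter), brought in a carboxy group in place of vinyl and lay beyond the scatter. Going by the values given here, the carboxy group now leaves with the (carboxymethyl)(methyl)amino group, so part of that improvement may be lost, although no measured step tests the entering group. The expected change in this assay is modest and towards a weaker inhibitor, an estimated 2.1-fold higher number from compound 2 to compound 3 (0.32 log units; beyond the scatter). For compound 3 the estimate is 12000 nM, with an expected range of 3000 nM to 50000 nM.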

Compound 3, half-maximal inhibitory concentration: 24800 nM
Compound 3: middle estimate off by 2.1-fold (0.32 log units), on the low side, and the stated range covers the measured number.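

On the carbonyl carbon, the choice of group clearly matters in this assay: replacing the (carboxymethyl)(methyl)amino group with the group of 7 heavy atoms gives a 4.3-fold higher number from compound 2 to compound 3 (0.64 log units; beyond the scatter). Set against the allyl-bearing amide of compound 1, the same group gives an at least 2.0-fold lower number from compound 1 to compound 3 (0.30 log units; that floor lies within the scatter), and this floor alone does not separate the two compounds. Compound 1 gives > 50000 nM, a limit of the assay and not a number, so the true size of that step stays unknown: the limit of > 50000 nM in this assay, at which 1 of the 3 values shown sits.

The step from compound 2 to compound 3 removes the carboxy group and brings in a new group at once, so the compounds shown cannot tell which of the two changes counts. A simple amine or a longer chain ending in a carboxylic acid on this carbonyl carbon would help separate them.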